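The source may report more compounds than this note shows. Statements on the series, on what has been measured and on what is new or still open speak of the compounds shown alone.

Compound 1, `C/C(=C\CC/C(C)=C/CC[C@@H]1[C@@]2(C)CCC(=O)C(C)(C)[C@H]2CC[C@@]1(C)O)CC/C=C(\C)C(=O)OCc1cn(-c2cccc(O)c2)nn1`: 42800 nM
Compound 2, `C/C(=C\CC/C(C)=C/CC[C@@H]1[C@@]2(C)CCC(=O)C(C)(C)[C@H]2CC[C@@]1(C)O)CC/C=C(\C)C(=O)OCc1cn(-c2ccccc2C)nn1`: > 150000 nM (a limit of the assay, not a number)
Compound 3, `C#CCOC(=O)/C(C)=C/CC/C(C)=C/CC/C(C)=C/CC[C@@H]1[C@@]2(C)CCC(=O)C(C)(C)[C@H]2CC[C@@]1(C)O`: 45100 nM

All three share one core and differ only in the ester end. In a functional assay on A549 cells (Homo sapiens) for antiproliferative activity, read by MTT assay, with a stated time of 48 h (a lower number here means a stronger inhibitor, a higher number a weaker inhibitor), compound 1 and compound 3 sit close together, the step of a 1.1-fold higher number from compound 1 to compound 3 (0.02 log units; within the scatter). Compound 2 stands apart: its value is only a limit, (the limit of > 150000 nM in this assay, at which 1 of the 3 values shown sits), so its true number is not known. The steps that touch it are both beyond the scatter, an at least 3.5-fold higher number from compound 1 to compound 2 (0.54 log units; beyond the scatter) and an at least 3.3-fold lower number from compound 2 to compound 3 (0.52 log units; beyond the scatter), and both lead away from compound 2 toward the weaker end.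

Compound 4, `C/C(=C\CC/C(C)=C/CC[C@@H]1[C@@]2(C)CCC(=O)C(C)(C)[C@H]2CC[C@@]1(C)O)CC/C=C(\C)C(=O)OCc1cn(-c2ccccc2C(F)(F)F)nn1`, differs from compound 2 in one place: trifluoromethyl in place of methyl on an aromatic carbon. For the measured compounds named here, no measured step alters this group, so nothing directly tells how this change moves the number. Going by the values given here, since compound 2 already sits at the limit and the only steps known from it go toward the weaker end, compound 4 is expected to remain at or near that limit, with a step of a number no higher from compound 2 to compound 4 (the limit leaves the size open) that is expected to be none beyond the scatter. Compound 4 is therefore estimated at 150000 nM, in the range 50000 nM to 400000 nM.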

Compound 4, half-maximal inhibitory concentration: > 150000 nM
Compound 4: no number, only a limit; the forecaster's own chance of this, stated with the estimate: 60%; the middle value lies on the limit itself.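

In this assay compound 4 gives > 150000 nM, which is a limit of the assay and not a number. Changing 3-hydroxyphenyl on the aromatic nitrogen to 2-(trifluoromethyl)phenyl gives an at least 3.5-fold higher number from compound 1 to compound 4 (0.54 log units; beyond the scatter), so a second group on this aromatic carbon, ortho to a large group, also ends on the weaker side. The step from methyl to trifluoromethyl itself cannot be read, because neither compound carries a number: the limit of > 150000 nM in this assay, at which 2 of the 4 values shown sit.

From the compounds shown here alone, the true numbers of compound 2 and compound 4 remain unknown, so the two groups cannot be ranked against each other. Going by these compounds, what an amine or a carboxylic acid on this aromatic carbon would give also stays open.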